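Two-carbon chain extension in a small ketone series

A few compounds are considered here, and "the series" means these few. Any claim that something is new, unique, unknown or untested is made for them only; others in the source may bear on it.

Measured so far:
compound 1 `CCOc1cc(OC)c(Br)cc1C(C)=O`, 37900000 nM
compound 2 `CCCCOc1cc(OC)c(Br)cc1C(C)=O`, 38200000 nM
compound 3 `CCCCCCCCCCCCOc1cc(OC)ccc1C(C)=O`, 28500000 nM

All three numbers come from a functional assay, with stated times of 30 s and 6 min, in the presence of a further agent that is not named here; a lower number here means a stronger inhibitor, a higher number a weaker inhibitor. Compound 2 differs from compound 1 by ethyl in place of hydrogen on a saturated chain carbon, two bonds along the chain from an oxygen on an aromatic ring, and the step of a 1.0-fold higher number from compound 1 to compound 2 (0.00 log units; within the scatter). Compound 3 has a different core; the difference between the core of compound 1 and the core of compound 3 is not broken down here. The three values in this assay sit within the scatter of one another, so no order among compound 1, compound 2 and compound 3 is drawn.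

Compound 4 `CCCCCCCCCCCCCCOc1cc(OC)ccc1C(C)=O` has not yet been measured. It differs from compound 3 by ethyl in place of hydrogen on a saturated chain carbon, ten or more bonds along the chain from an oxygen on an aromatic ring. For the measured compounds named here, this is the same kind of change as the one from compound 1 to compound 2, though not the same change: the ethyl enters at a different place along the chain in each case, as the two differences above state. Because a 1.0-fold higher number from compound 1 to compound 2 (0.00 log units; within the scatter) lies within the scatter, the step expected in this assay is a 1.1-fold lower number from compound 3 to compound 4 (0.02 log units; within the scatter). For compound 4 the estimate is 27000000 nM, expected to lie between 13000000 nM and 56000000 nM.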

Compound 4, half-maximal inhibitory concentration: 35900000 nM
Compound 4: middle estimate off by 1.3-fold (0.12 log units), on the low side; the measured number falls inside the stated range.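

In this assay, ethyl in place of hydrogen on the longer chain gives a 1.3-fold higher number from compound 3 to compound 4 (0.10 log units; within the scatter), and the step stays within the scatter, as the step on the shorter chain did. Set side by side, the steps on the two cores show no difference: the same change on two cores in this assay, a 1.0-fold higher number (0.00 log units; within the scatter) from compound 1 to compound 2 and a 1.3-fold higher number (0.10 log units; within the scatter) from compound 3 to compound 4, 1.2-fold (0.10 log units) apart, within the scatter of two such steps

This shows that, for these two pairs, the change carries from one core to the other without a step that can be told from scatter, but it does not show that the change is without effect on any other core or chain, and the ethyl also enters at a different place along the chain in each pair, so core and place cannot be separated here. The compounds shown leave open whether a chain ending in an amine or a carboxylic acid would give a number beyond the scatter of these values in this assay. For the compounds shown here, they also leave open what the bromo group contributes, as no pair here differs in that one place.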